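Swapping a Morpholine Amide for a Methyl Amide

This account rests on a few compounds, and the source may have more. Where it says the series, first, only, none or still open, it means among the compounds named here.

Compound 1 `CNC(=O)/C=C/c1ccncc1-c1ccc2cc[nH]c2c1` and compound 2 `O=C(/C=C/c1ccncc1-c1ccc2cc[nH]c2c1)N1CCOCC1` share one core and differ by methylamino in place of morpholin-4-yl on a carbonyl carbon. In a functional assay on MDA-MB-231 cells (Homo sapiens) for inhibition, read by sulforhodamine B assay, with a stated time of 72 h (a lower number here means a stronger inhibitor of growth, a higher number a weaker inhibitor of growth), compound 1 gives 7680 nM. Compound 2 reaches only a limit of the assay, > 10000 nM. The step of an at least 1.3-fold lower number from compound 2 to compound 1 (0.11 log units; that floor lies within the scatter) therefore rests on (the limit of > 10000 nM in this assay, at which 2 of the 3 values shown sit). Compound 3 `O=C(CCc1ccncc1-c1ccc2ccccc2c1)N1CCOCC1` carries a different core, and the difference between the two cores is not broken down here. Compound 3 also reaches only a limit of the assay, > 10000 nM. Compound 4 `CNC(=O)CCc1ccncc1-c1ccc2ccccc2c1` differs from compound 3 by methylamino in place of morpholin-4-yl on a carbonyl carbon, the same kind of change, though here the carbonyl carbon's other neighbour is a saturated chain carbon rather than a double-bonded chain carbon. A similarly modest step is expected, a step that the limit leaves unreadable from compound 3 to compound 4. That expectation rests on an at least 1.3-fold lower number from compound 2 to compound 1 (0.11 log units; that floor lies within the scatter). Compound 4 is expected to give about 12000 nM, likely between 4000 nM and 40000 nM.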

Compound 4, concentration for 50% growth inhibition: 8980 nM
Estimate against measurement, compound 4: 1.3-fold (0.13 log units) above; measured number inside the range.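

In this assay, putting methylamino in place of morpholin-4-yl on the carbonyl carbon of the saturated chain gives an at least 1.1-fold lower number from compound 3 to compound 4 (0.04 log units; that floor lies within the scatter). Carried from one core to the other, the change gives a number rather than a limit each time, but neither step can be sized, and no difference between them can be claimed: the same change on two cores in this assay, an at least 1.3-fold lower number (0.11 log units; that floor lies within the scatter) from compound 2 to compound 1 and an at least 1.1-fold lower number (0.04 log units; that floor lies within the scatter) from compound 3 to compound 4; the limit leaves it open whether they differ The morpholine amides, compound 2 and compound 3, both stop at the assay's limit, so the data show no real gain from this change on either core: the limit of > 10000 nM in this assay, at which 2 of the 4 values shown sit.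

From the compounds shown here alone, it remains open whether an ethylamino or dimethylamino group on the same carbonyl carbon would give a clearly lower number. A carboxylic acid in place of the amide is also untested among the compounds shown.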